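Cyclopentyl to cyclohexyl amides in a weakly active series

A few compounds are considered here, and "the series" means these few. Any claim that something is new, unique, unknown or untested is made for them only; others in the source may bear on it.

Compound 1 `CC(C)C(NC(=O)NO)C(=O)NC1CCCCC1` and compound 2 `CC(C)C(NC(=O)NO)C(=O)NC1CCCC1` share a hydroxyurea-bearing core and differ only in the ring on the amide nitrogen. In a functional assay on L1210 cells (Mus musculus) for inhibition (a lower number here means a stronger inhibitor, a higher number a weaker inhibitor), compound 1 reaches only a limit, > 100000 nM. In this assay compound 2 likewise reaches only a limit, > 200000 nM. The change from compound 2 to compound 1 is cyclohexyl in place of cyclopentyl on an amide-type nitrogen; its step, a step that the two limits leave unreadable from compound 2 to compound 1, cannot be sized, since both ends sit at limits (the limit of > 100000 nM in this assay, at which 1 of the 3 values shown sits, and (the limit of > 200000 nM in this assay, at which 2 of the 3 values shown sit)).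

Compound 3 `CC(C)C(NC(=O)n1nnc2ccccc21)C(=O)NC1CCCC1` carries a different core; how this core differs from that of compound 2 is not broken down here. In this assay compound 3 also reaches only a limit, > 200000 nM.

Compound 4 `CC(C)C(NC(=O)n1nnc2ccccc21)C(=O)NC1CCCCC1` is yet to be measured. It differs from compound 3 by cyclohexyl in place of cyclopentyl on an amide-type nitrogen, the same kind of change as from compound 2 to compound 1, and the place line is the same word for word. For the measured compounds named here, since none of the three measured compounds gives a number in this assay, and the one measured instance of this change does not move a compound off its limit, compound 4 is expected to stay at a limit as well. The step from compound 3 to compound 4 is estimated as a step that the limit leaves unreadable from compound 3 to compound 4, essentially flat. For compound 4 the estimate is 250000 nM, within 100000 nM to 1000000 nM, most probably reported only as a limit.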

Compound 4, half-maximal inhibitory concentration: 108000 nM
Compound 4: the middle estimate sits 2.3-fold (0.36 log units) above what was measured; the measured number falls inside the stated range.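

Carrying cyclohexyl in place of cyclopentyl on an amide-type nitrogen onto the core of compound 3 gives, in this assay, an at least 1.8-fold lower number from compound 3 to compound 4 (0.26 log units; that floor lies within the scatter), so the only thing this change shows on that core is a floor that does not clear the scatter, while compound 4 is the only one of the four with a number rather than a limit. The same change on the core of compound 2 cannot be read, and the sizes on the two cores therefore cannot be compared, because compound 1 rests on a limit and compound 2 on another: the limit of > 100000 nM in this assay, at which 1 of the 4 values shown sits. The limit at the other end of the new step, that of compound 3, also leaves its true size unknown, so these compounds neither show that the change carries from one core to the other nor show that it fails to: the limit of > 200000 nM in this assay, at which 2 of the 4 values shown sit.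

As far as these compounds go, whether a larger ring such as cycloheptyl, or an open chain such as n-hexyl, on the same amide-type nitrogen would move the number further in this assay remains open. So does the effect of a group such as a carboxylic acid or an amine at that place on either core.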